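Swapping the Ring on Compound 1's Amide Nitrogen

The source may report more compounds than this note shows. Statements on the series, on what has been measured and on what is new or still open speak of the compounds shown alone.

Of the compounds shown here, two have been measured for solubility so far. Compound 1 `CCC/N=C1\S/C(=C\c2ccc(O)c(Cl)c2)C(=O)N1C1CCOCC1` gives in a physicochemical assay for solubility, measured as kinetic solubility (on this read-out lower numbers stand for lower solubility and higher numbers for higher solubility), a value of 70000 nM. Compound 2 `CCC/N=C1\S/C(=C\c2ccc(O)c(C(F)(F)F)c2)C(=O)N1c1ccccc1C` differs from compound 1 in more than one place. In this assay compound 2 gives a value of 14000 nM. Of the two numbers, compound 1 stands higher, and its gap to compound 2 lies beyond the scatter of repeated measurements. Compound 1 and compound 2 differ in several places at once. For the measured compounds named here, no single step between them can be drawn, and the two values can only be set side by side.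

The next compound, compound 3 `CCC/N=C1\S/C(=C\c2ccc(O)c(Cl)c2)C(=O)N1C1CCN(C)C(=O)C1`, changes compound 1 in one place only: 1-methyl-2-oxopiperidin-4-yl in place of oxan-4-yl on an amide-type nitrogen in a ring. Going by the values given here, no measured pair in this set shows that change, so there is no step to lean on. For compound 3 the expected step is a 1.4-fold higher number from compound 1 to compound 3 (0.15 log units; within the scatter), a small move upward that may well stay within the scatter. In this assay compound 3 is therefore estimated at 100000 nM, with a plausible range from 40000 nM to 250000 nM.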

Compound 3, solubility: > 250000 nM
Compound 3 gave a limit, no number (the forecaster's own chance of this, stated with the estimate: 10%); at least 2.5-fold (0.39 log units) between middle value and limit.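

The position on the amide-type nitrogen, two ring bonds from the ring sulfur, now has its first single-place step in this assay: 1-methyl-2-oxopiperidin-4-yl in place of oxan-4-yl gives an at least 3.5-fold higher number from compound 1 to compound 3 (0.55 log units; beyond the scatter). Compound 3 reads > 250000 nM, which is a limit of the assay and not a number. The two groups match in hydrogen-bond donors, hydrogen-bond acceptors and net charge and differ in heavy atoms, and the step marks only the least size of the change, with its full size unknown: the limit of > 250000 nM in this assay, at which 1 of the 3 values shown sits.

The compounds shown leave open how far compound 3 truly lies from compound 1 and which part of the entering group goes with the rise. A plain 1-methylpiperidin-4-yl without the carbonyl, or an open alkyl chain on the same nitrogen, would be needed to tell whether the ring carbonyl, the ring nitrogen with its methyl, or neither of them goes with this step.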